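tert-Butyl in Place of Methyl on an Aromatic Nitrogen

The source may report more compounds than this note shows. Statements on the series, on what has been measured and on what is new or still open speak of the compounds shown alone.

Of the compounds shown here, two with the shared core have been measured so far. In a physicochemical assay for acid dissociation, compound 1 `C=CCCOC[n+]1ccn(C)c1/C=N/O` gives 7.97, and compound 2 `C#CCCCC[n+]1ccn(C)c1/C=N/O` gives 8.18. These two values lie within the usual scatter of each other, so compound 2 cannot be separated from compound 1 on these numbers.

The next compound, compound 3 `C#CCCCC[n+]1ccn(C(C)(C)C)c1/C=N/O`, keeps the pent-4-yn-1-yl chain of compound 2 and differs in one place: tert-butyl in place of methyl on an aromatic nitrogen. This is tert-butyl in place of methyl on an aromatic nitrogen. Among the measured compounds shown here, no measured pair varies the group at this place, so the data give no direct guide to the change. For the measured compounds named here, the only measured step, a number 0.21 log units higher from compound 1 to compound 2 (within the scatter), lies on a saturated chain carbon bound to an aromatic nitrogen, elsewhere in the molecule. It offers only a weak hint that this assay may not move much, so no shift beyond the scatter is expected. The estimated change is a number 0.02 log units higher from compound 2 to compound 3 (within the scatter). Compound 3 is expected at 8.2, with an estimated range from 7.8 to 8.6.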

Compound 3, acid dissociation constant: 8.06
The estimate for compound 3 lay 0.14 log units above the measured number; measured number inside the range.
By their numbers in this assay, from the lowest: compounds 1, 3 and 2 (each within the scatter of the next).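

Among the compounds shown here, this is the first measured step at the group on this aromatic nitrogen. In this assay, tert-butyl in place of methyl gives a number 0.12 log units lower from compound 2 to compound 3 (within the scatter), so compound 2 and compound 3 cannot be told apart on these numbers, even though the group grows from 1 heavy atom to 4. At least for these two plain carbon groups, with no ring and no hydrogen-bond donors or acceptors, the size of the group at this place does not separate the compounds in this read-out, and nothing measured here bears on the reason for this result.

Only methyl and tert-butyl are shown on this nitrogen, so it remains open whether a group with atoms other than carbon, such as an amine or a carboxylic acid, or a ring such as phenyl, would also stay within the scatter. Also open is whether tert-butyl in place of methyl would give a similarly small step alongside the (but-3-en-1-yl)oxy group of compound 1, as the swap is shown here only with the pent-4-yn-1-yl chain.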